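Ester substituents on a saturated ring carbon: plasma stability notes

The source may report more compounds than this note shows. Statements on the series, on what has been measured and on what is new or still open speak of the compounds shown alone.

Measured so far:
compound 1 `CC(=O)N1CCN(S(=O)(=O)c2ccc(F)cc2)CC1` — >= 4 h
compound 2 `CC(=O)OCC1CN(C(C)=O)CCN1S(=O)(=O)c1ccc(F)cc1` — 0.483 h

In an ADME assay on a cell-free system (plasma, Rattus norvegicus, strain Sprague-Dawley) for metabolic stability, read by LC-MS, tested at 1 uM (on this read-out lower numbers stand for a shorter-lived compound and higher numbers for a longer-lived compound), compound 1 gives >= 4 h; this is a limit of the assay, not a number, compound 1 sitting at the limit of >= 4 h in this assay, at which 1 of the 2 values shown sits. Compound 2 gives 0.483 h in this assay, so the step from the parent is an at least 8.2-fold lower number from compound 1 to compound 2 (0.91 log units; beyond the scatter). Compound 3 `CCOC(=O)C1CN(S(=O)(=O)c2ccc(F)cc2)CCN1C(C)=O` is not yet measured; it differs from compound 1 by ethoxycarbonyl in place of hydrogen on a saturated ring carbon. For the measured compounds named here, the only step that bears on this change is an at least 8.2-fold lower number from compound 1 to compound 2 (0.91 log units; beyond the scatter), also a substituent entering on a saturated ring carbon, and on that basis a shorter half-life is expected for compound 3, an at least 4.0-fold lower number from compound 1 to compound 3 (0.60 log units; beyond the scatter). Compound 3 is estimated at 1 h, range 0.3 h to 4 h.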

Compound 3, half-life in the plasma assay: 0.617 h
For compound 3 the middle estimate is 1.6-fold (0.21 log units) above the measured one; measured number inside the range.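

In the plasma assay, ethoxycarbonyl in place of hydrogen on a saturated ring carbon gives an at least 6.4-fold lower number from compound 1 to compound 3 (0.81 log units; beyond the scatter), so the short half-life seen with acetoxymethyl is not confined to that one ester substituent. In a physicochemical assay for metabolic stability, read by LC-MS, in phosphate buffer, tested at 1 uM (a higher number here means that the compound lasts longer, a lower number that the compound disappears faster), compound 1 gives >= 4 h, which is a limit of the assay. In the physicochemical assay compound 3 gives >= 4 h, which is a limit of the assay. The step between compound 1 and compound 3 in that assay cannot be read, and no shortening shows there: the limit of >= 4 h in the physicochemical assay, at which 2 of the 2 values shown sit.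

Open, on these data alone, is whether the shortening requires an ester at all. A carboxylic acid or a plain methyl on this ring carbon would test that.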